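Piperidin-1-yl in place of (4-chlorophenyl)amino on compound 3

The source may hold more compounds than are shown below. What is called first, only, known or untested is meant among the compounds shown, and "the series" means these compounds.

In a functional assay on A549 cells (Homo sapiens) for inhibition, with a stated time of 72 h (a higher number here means a weaker inhibitor, a lower number a stronger inhibitor), compound 3 `O=C(Nc1ccccc1)Nc1nc(Nc2ccc(Cl)cc2)cc(Sc2c[nH]c3ccccc23)n1` gives 48400 nM as the highest of three numbers, while compound 1 `COc1ccc(NC(=O)Nc2nc(Sc3c[nH]c4ccccc34)cc(N3CCCCC3)n2)cc1` gives 13500 nM and compound 2 `O=C(Nc1ccc(Cl)cc1)Nc1nc(Sc2c[nH]c3ccccc23)cc(N2CCCCC2)n1` gives 18600 nM with piperidin-1-yl already in place. Compound 4 `O=C(Nc1ccccc1)Nc1nc(Sc2c[nH]c3ccccc23)cc(N2CCCCC2)n1` follows from compound 3 by piperidin-1-yl in place of (4-chlorophenyl)amino on an aromatic carbon with piperidin-1-yl in place of (4-chlorophenyl)amino on an aromatic carbon. For the measured compounds named here, no measured step isolates this exchange. Going by the values given here, the one measured step, a 1.4-fold higher number from compound 1 to compound 2 (0.14 log units; within the scatter) for chloro in place of methoxy on an aromatic carbon, suggests that compound 4 should sit near compound 1 and compound 2. The expected change is a 2.8-fold lower number from compound 3 to compound 4 (0.45 log units; beyond the scatter) and so beyond the scatter. The estimate for compound 4 is 17000 nM with an expected range of 8000 nM to 35000 nM in these notes.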

Compound 4, half-maximal inhibitory concentration: 33100 nM
For compound 4 the middle estimate is 1.9-fold (0.29 log units) below the measured one; low and high end bracket the measured number.
By their numbers in this assay, from the lowest: compounds 1, 2, 4 and 3 (each within the scatter of the next, the first and the last beyond it).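

In this assay this position does not separate (4-chlorophenyl)amino from piperidin-1-yl (a 1.5-fold lower number from compound 3 to compound 4 (0.17 log units; within the scatter)). With piperidin-1-yl in place, hydrogen in place of chloro is also unresolved (a 1.8-fold higher number from compound 2 to compound 4 (0.25 log units; within the scatter)), whereas hydrogen in place of methoxy gives a modest separation (a 2.5-fold higher number from compound 1 to compound 4 (0.39 log units; beyond the scatter)). No independent measurement on hand bears on these steps.

Open, from the compounds shown here alone, is whether morpholin-4-yl or dimethylamino at this position would give a clearer separation. Also open, going by these compounds, is how a carboxylic acid on the phenyl ring of the (phenylcarbamoyl)amino group would compare with hydrogen, chloro and methoxy.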